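Swapping the aryl on the triazole nitrogen: a third analogue

A few compounds are considered here, and "the series" means these few. Any claim that something is new, unique, unknown or untested is made for them only; others in the source may bear on it.

Compound 1 `CCOc1ccccc1-n1nncc1CN1C(=O)C2(C(C#N)=C(N)Oc3c(N)cc4nc5ccccc5nc4c32)c2ccccc21` — in an ADME assay on L02 cells (Homo sapiens) for antiproliferative activity, read by MTT assay, with a stated time of 48 h (a lower number here means a stronger inhibitor, a higher number a weaker inhibitor), compound 1 gives > 50000 nM, which is a limit of the assay and not a number.
Compound 2 `Cc1cc(C)cc(-n2nncc2CN2C(=O)C3(C(C#N)=C(N)Oc4c(N)cc5nc6ccccc6nc5c43)c3ccccc32)c1` — in this assay compound 2 gives > 50000 nM, likewise only a limit.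

Among the measured compounds shown here, compound 2 thus stands at the limit in this assay, and the one measured step, a step that the two limits leave unreadable from compound 1 to compound 2, has no readable size because both of its ends sit at the limit of > 50000 nM in this assay, at which 2 of the 2 values shown sit. The new analogue, compound 3 `N#CC1=C(N)Oc2c(N)cc3nc4ccccc4nc3c2C12C(=O)N(Cc1cnnn1-c1ccc(Cl)cc1Cl)c1ccccc12`, arises through (2,4-dichlorophenyl in place of 3,5-dimethylphenyl on an aromatic nitrogen). For the measured compounds named here, the only measured step that bears on an exchange of the aryl group on that aromatic nitrogen is the unreadable one from compound 1 to compound 2, so neither size nor direction can be drawn from it; all that the two measured compounds show is that both remain at the limit. Compound 3 is therefore expected to stay there too, with a step that the limit leaves unreadable from compound 2 to compound 3 estimated to be none beyond the scatter. Compound 3 is estimated at 70000 nM, in a range from 30000 nM to 200000 nM, most probably again reported only as a limit.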

Compound 3, half-maximal inhibitory concentration: > 50000 nM
Compound 3: no number, only a limit; the forecaster's own chance of this, stated with the estimate: 85%; the middle value is on the limit's open side.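

In this assay compound 3 gives > 50000 nM, a limit of the assay and not a number. No step among compound 1, compound 2 and compound 3 can be read, because all three sit at the same limit: the limit of > 50000 nM in this assay, at which 3 of the 3 values shown sit.

The compounds shown leave open whether any aryl group on that aromatic nitrogen gives a measurable value in this assay.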